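Aryl halogen swap in a three-carbon amide series

This account rests on a few compounds, and the source may have more. Where it says the series, first, only, none or still open, it means among the compounds named here.

Compound 1 `CC(=O)NCCCc1cccc(F)c1` gives 1920 nM in an assay for binding affinity to melatonin receptor (Gallus gallus); on this read-out higher numbers stand for weaker inhibition and lower numbers for stronger inhibition. Among the compounds with values here, compound 2 `CCCC(=O)NCCCc1cccc(F)c1` gives 434 nM in this assay, the lower of the two numbers so far, and the step of a 4.4-fold lower number from compound 1 to compound 2 (0.65 log units; beyond the scatter) is the only measured step. Compound 3 `CCCC(=O)NCCCc1cccc(Cl)c1` differs from compound 2 by chloro in place of fluoro on an aromatic carbon. Within the data shown here, no measured step touches the aryl halogen; the single step in hand concerns the amide chain and so does not bear on this change. The step of a 1.0-fold lower number from compound 2 to compound 3 (0.00 log units; within the scatter) is therefore expected to stay within the scatter. Compound 3 is estimated at 430 nM, range 150 nM to 1200 nM.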

Compound 3, inhibition constant: 113 nM
The estimate for compound 3 lay 3.8-fold (0.58 log units) above the measured number; the whole stated range lies above it.
By their numbers in this assay, from the lowest: compound 3; then compound 2; then compound 1.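

The ring position carrying the halogen is not silent in this assay: chloro in place of fluoro gives a 3.8-fold lower number from compound 2 to compound 3 (0.58 log units; beyond the scatter). The amide chain and the aryl halogen have now each given a step beyond the scatter, and in both the number falls. No available evidence accounts for the difference between fluoro and chloro at this position.

Going by these compounds, whether bromo or iodo on the same aromatic carbon would lower the number further remains open. So does whether a longer chain on the amide would lower it again with chloro in place.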